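Chalcone-pyrazole series: switching the aryl ketone substituent

This account rests on a few compounds, and the source may have more. Where it says the series, first, only, none or still open, it means among the compounds named here.

Measured so far:
compound 1 `COc1ccc(C(=O)/C=C/c2cc(-c3cc(OC)c(OC)c(OC)c3)n[nH]2)cc1OC` gives 71%
compound 2 `COc1ccc(C(=O)/C=C/c2cc(-c3cc(OC)c(OC)c(OC)c3)n[nH]2)cc1` gives 76%

Both numbers come from a functional assay on PC-3 cells (Homo sapiens) for cytotoxicity, read by sulforhodamine B assay, with a stated time of 48 h, tested at 1 uM; a lower number here means a stronger effect, a higher number a weaker effect of the compound at the concentration tested. Among the measured compounds shown here, compound 2 stands highest of the two, with compound 1 nearest to it; the only counted step, a number 5 percentage points higher from compound 1 to compound 2 (within the scatter), stays inside the scatter, so the two compounds cannot be ordered on this read-out.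

The next compound, compound 3 `COc1cc(-c2cc(/C=C/C(=O)c3ccc(F)c(F)c3)[nH]n2)cc(OC)c1OC`, has not yet been measured in this assay. It differs from compound 2 in one place: 3,4-difluorophenyl in place of 4-methoxyphenyl on a carbonyl carbon. For the measured compounds named here, no measured step swaps one aryl group for another on the carbonyl carbon; the only step in hand, a number 5 percentage points higher from compound 1 to compound 2 (within the scatter), touches the same aryl ring but removes a single methoxy, and it was small. Nothing seen so far points to a move beyond the scatter in this assay.

Compound 3 is therefore expected to land close to compound 2, with an estimated step of a number 2 percentage points lower from compound 2 to compound 3 (within the scatter). The estimate for compound 3 is 74%, with a range from 55% to 92%.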

Compound 3, a percentage reported as activity, at one concentration (the size of the read-out at that concentration, not a potency): 70%
Compound 3: middle estimate off by 4 percentage points, on the high side, and the stated range covers the measured number.
By their numbers in this assay, from the lowest: compounds 3, 1 and 2 (each within the scatter of the next).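

In this assay, the carbonyl-bound aryl group was exchanged outright rather than trimmed by one methoxy, and the exchange of 4-methoxyphenyl for 3,4-difluorophenyl gives (a number 6 percentage points lower from compound 2 to compound 3 (within the scatter)), while the exchange of 3,4-dimethoxyphenyl for the same group gives (a number 1 percentage points lower from compound 1 to compound 3 (within the scatter)). Neither step can be told from no change, so this position on the carbonyl carbon accepts a ring carrying fluorine in place of one carrying methoxy without a readable shift, and a methoxy on this ring is not needed to keep the read-out in the range of compound 1 and compound 2. Nothing available explains why the read-out stays flat across these three rings, and no measurement other than this one bears on the result.

Open, from the compounds shown here alone, is whether any group on the carbonyl carbon can move this assay beyond the scatter at all, since all three compounds here carry a substituted phenyl ring. A phenyl ring bearing a dimethylamino group or a carboxylic acid, or a pyridine ring in place of the phenyl ring, would test whether this position is truly insensitive.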